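A few compounds are considered here, and "the series" means these few. Any claim that something is new, unique, unknown or untested is made for them only; others in the source may bear on it.

Measured compounds:
compound 1 `COc1ncc(-c2ccc3nc(NC(=O)NC4CC4)nn3c2)cc1NS(=O)(=O)c1ccc(F)cc1` gives 540 nM in a functional assay on U-87MG ATCC cells for cytotoxicity against U-87 MG (Homo sapiens), read by MTT assay, with a stated time of 72 h; on this read-out lower numbers stand for stronger inhibition and higher numbers for weaker inhibition;
compound 2 `CCN(CC)CCNC(=O)Nc1nc2ccc(-c3cnc(OC)c(NS(=O)(=O)c4ccc(C)cc4)c3)cn2n1` gives 670 nM in this assay;
compound 3 `CCN(CC)CCNC(=O)Nc1nc2ccc(-c3cnc(OC)c(NS(=O)(=O)c4ccc(F)cc4F)c3)cn2n1` gives 1060 nM in this assay.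

Compound 1 has the lowest number of the three, yet compound 2 and compound 3 sit within the scatter of it. Compound 4 `COc1ncc(-c2ccc3nc(NC(=O)NCCN4CCCCC4)nn3c2)cc1NS(=O)(=O)c1ccc(F)cc1` arises from compound 1 by a change on the urea: 2-(piperidin-1-yl)ethyl in place of cyclopropyl on an amide-type nitrogen. For the measured compounds named here, no measured step touches this position. Going by the values given here, the one measured step, a 1.6-fold higher number from compound 2 to compound 3 (0.20 log units; within the scatter), concerns the sulfonyl side. Compound 2 and compound 3 both carry a chain-type amine on the urea nitrogen and give numbers close to compound 1, so no step beyond the scatter is expected. The estimated 1.1-fold higher number from compound 1 to compound 4 (0.05 log units; within the scatter) is small, and compound 4 is expected near 600 nM, between 250 nM and 1500 nM.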

Compound 4, half-maximal inhibitory concentration: 1080 nM
The estimate for compound 4 lay 1.8-fold (0.26 log units) below the measured number; the range from low to high includes it.
By their numbers in this assay, from the lowest: compounds 1, 2, 3 and 4 (each within the scatter of the next).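

For the compounds shown here, this is the first measured step on the amide-type nitrogen of the urea: in this assay, 2-(piperidin-1-yl)ethyl in place of cyclopropyl gives a 2.0-fold higher number from compound 1 to compound 4 (0.30 log units; within the scatter). This assay therefore does not separate the small carbon ring from the larger group with its added nitrogen, at least on the core of compound 1. No supporting measurement bears on this result.

Still open, as far as these compounds go, is whether a longer chain ending in the same 2-(piperidin-1-yl)ethyl-type amine, or a chain ending in a carboxylic acid, would also stay within the scatter of compound 1.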